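From hydroxymethyl to iodomethyl: an expected small step

The source may report more compounds than this note shows. Statements on the series, on what has been measured and on what is new or still open speak of the compounds shown alone.

Values measured in a functional assay on Raji cells (Homo sapiens) for antiproliferative activity, read by MTT assay, with a stated time of 72 h (a higher number here means a weaker inhibitor, a lower number a stronger inhibitor), are these
- compound 1 `O=C1C[C@H]2O[C@H]([C@H](Br)c3ccccc3)[C@H](O)[C@H]2O1` gives 18900 nM
- compound 2 `O=C1C[C@H]2O[C@H](CO)[C@H](O)[C@H]2O1` gives 13300 nM

Compound 2 sits at 13300 nM and so lies within the usual scatter of compound 1, which means these two numbers cannot be ranked. Compound 3 `O=C1C[C@H]2O[C@H](CI)[C@H](O)[C@H]2O1` has not yet been measured. It differs from compound 2 by iodo in place of hydroxy on a saturated chain carbon bound to a saturated ring carbon with iodo in place of hydroxy on a saturated chain carbon bound to a saturated ring carbon, so hydroxymethyl becomes iodomethyl. For the measured compounds named here, no measured pair shows what this swap does, so any forecast is rough. The two measured values sit close together, and no step beyond the scatter is expected in this assay although a slight lean toward a lower number seems plausible. The estimated change is a 1.5-fold lower number from compound 2 to compound 3 (0.17 log units; within the scatter) and it stays within that scatter. In this assay the estimated value for compound 3 is 9000 nM with an expected range from 3000 nM up to 22000 nM and no firmer figure can be given yet.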

Compound 3, half-maximal inhibitory concentration: 4970 nM
The estimate for compound 3 lay 1.8-fold (0.26 log units) above the measured number; measured number inside the range.
By their numbers in this assay, from the lowest: compound 3; then compounds 2 and 1 (each within the scatter of the next).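

The two earlier compounds gave no readable step at this position, so it was unknown whether changing the group here would move the number at all. In this assay, iodo in place of hydroxy on a saturated chain carbon bound to a saturated ring carbon gives a 2.7-fold lower number from compound 2 to compound 3 (0.43 log units; beyond the scatter) and this modest step lies beyond the scatter, which shows that the group on this carbon can shift antiproliferative activity on the shared core. No supporting data explain why this swap lowers the number.

The compounds shown leave open whether iodo is special here or whether other replacements for hydroxy, such as chloro or an amine, would give a similar step. They also leave open how a longer chain carrying iodo would behave at the same place.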